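The compounds below may be only part of what the source reports. "The series", "measured", "known", "first", "only" and "open" are said of these compounds alone.

Measured in a functional assay on the whole organism (strain Sprague-Dawley) for inhibition, with Rattus norvegicus as the target, with a stated time of 10 min; a lower number here means that less compound is needed, a higher number that more compound is needed for the effect:
- compound 1 `CCOc1ccc(OC)cc1-c1ncc(C(=O)O)c(=O)[nH]1`: 0.2 mg/kg
- compound 2 `CCOc1ccc(N(C)C)cc1-c1ncc(C(=O)O)c(=O)[nH]1`: 0.3 mg/kg
- compound 3 `CCOc1ccc(S(=O)(=O)Cl)cc1-c1ncc(C(=O)O)c(=O)[nH]1`: "not determined" (no result reported)

Compound 3 has no number in this assay, so the step to compound 4 `CCOc1ccc(S(=O)(=O)N(CC)CC)cc1-c1ncc(C(=O)O)c(=O)[nH]1` has no measured starting point. The change is diethylamino in place of chloro on a sulfonyl sulfur. For the measured compounds named here, no measured step covers this change. Going by the values given here, the only measured step, a 1.5-fold higher number from compound 1 to compound 2 (0.18 log units; within the scatter), is dimethylamino in place of methoxy on an aromatic carbon, and it bears on this change only loosely. No size or direction of step can therefore be expected from compound 3, and the estimate rests on the level of compound 1 at 0.2 mg/kg and compound 2 at 0.3 mg/kg, with a wide range. The expected value for compound 4 is 0.5 mg/kg, with an estimated range of 0.1 mg/kg to 3 mg/kg.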

Compound 4, dose for 50% inhibition: 40 mg/kg
For compound 4 the middle estimate is 80-fold (1.90 log units) below the measured one, and the stated range ends below it.
By their numbers in this assay, from the lowest: compounds 1 and 2 (each within the scatter of the next); then compound 4.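

In this assay this aromatic carbon is not indifferent to its substituent: diethylsulfamoyl brings a 130-fold higher number from compound 2 to compound 4 (2.12 log units; beyond the scatter), and a 200-fold higher number from compound 1 to compound 4 (2.30 log units; beyond the scatter). Methoxy and dimethylamino, whose values lie within the scatter of each other, gave no sign of such sensitivity at this position. Nothing measured here accounts for the rise.

The change from chlorosulfonyl to diethylsulfamoyl cannot be read, as compound 3 has no number. Open, as far as these compounds go, is whether the loss follows the sulfonyl link or the diethylamino part, which an unsubstituted sulfonamide or a methylsulfonyl group would help separate.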